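Hydrazone aryl variation on the triazolyl pyridyl ether urea series

A few compounds are considered here, and "the series" means these few. Any claim that something is new, unique, unknown or untested is made for them only; others in the source may bear on it.

Among the measured compounds shown here, compound 1 `CN(C)CCn1cnnc1-c1cc(Oc2ccc(NC(=O)N/N=C/c3cccc(Br)c3)cc2F)ccn1` is the reference point; in a functional assay on HT-29 cells (Homo sapiens) for cytotoxicity, read by MTT assay, with a stated time of 72 h (on this read-out lower numbers stand for stronger inhibition and higher numbers for weaker inhibition), compound 1 gives 380 nM, the lowest of the three numbers so far. Compound 2 `CN(C)CCn1cnnc1-c1cc(Oc2ccc(NC(=O)N/N=C/c3c(O)ccc4ccccc34)cc2F)ccn1` gives 670 nM and compound 3 `Cc1cc(/C=N/NC(=O)Nc2ccc(Oc3ccnc(-c4nncn4CCN(C)C)c3)c(F)c2)cc(C)c1O` gives 1220 nM. The two steps away from compound 1 both replace the 3-bromophenyl on the carbon with a double bond to nitrogen: a 1.8-fold higher number from compound 1 to compound 2 (0.25 log units; within the scatter), and a 3.2-fold higher number from compound 1 to compound 3 (0.51 log units; beyond the scatter). Between the two hydroxyl-bearing aryls the gap is a 1.8-fold higher number from compound 2 to compound 3 (0.26 log units; within the scatter).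

Compound 4 `CN(C)CCn1cnnc1-c1cc(Oc2ccc(NC(=O)N/N=C/c3c(Cl)cccc3Cl)cc2F)ccn1` is the next step from compound 1, again at the same carbon: 2,6-dichlorophenyl in place of 3-bromophenyl on a carbon with a double bond to nitrogen. Unlike the two measured steps, no hydroxyl enters; the group that enters, like the one that leaves, is a phenyl bearing only halogen. The measured steps therefore bear on it only loosely, and both were modest or within scatter. A small rise in number, at most comparable to the step to compound 2, is expected, a 1.2-fold higher number from compound 1 to compound 4 (0.07 log units; within the scatter). Compound 4 is estimated at 450 nM, with a range from 180 nM to 1100 nM.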

Compound 4, half-maximal inhibitory concentration: 280 nM
For compound 4 the middle estimate is 1.6-fold (0.21 log units) above the measured one, within the range that was stated.
By their numbers in this assay, from the lowest: compounds 4, 1, 2 and 3 (each within the scatter of the next, the first and the last beyond it).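

In this assay the 2,6-dichlorophenyl on the carbon with a double bond to nitrogen cannot be told apart from the 3-bromophenyl (a 1.4-fold lower number from compound 1 to compound 4 (0.13 log units; within the scatter)), so exchanging one bromine for two chlorine leaves the halogen-only phenyl level with the reference. The new group is separated from both hydroxyl-bearing aryls (a 2.4-fold lower number from compound 2 to compound 4 (0.38 log units; beyond the scatter) and a 4.4-fold lower number from compound 3 to compound 4 (0.64 log units; beyond the scatter)), whereas compound 1 was separated only from compound 3 and stayed within the scatter of compound 2. No measurement at hand accounts for these differences.

Still open, from the compounds shown here alone, is whether a phenyl carrying an amine or a carboxylic acid would stay level with compound 1 and compound 4 or fall nearer compound 3. Also open, going by these compounds, is where an unsubstituted phenyl would fall on this carbon.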